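Methoxy to hydroxy on the shared core: an open step

A few compounds are considered here, and "the series" means these few. Any claim that something is new, unique, unknown or untested is made for them only; others in the source may bear on it.

Going by the values given here, compound 2 `COc1ccc2c(=O)cc(C(=O)Nc3nnn[nH]3)oc2c1` gives 0.048 ug/mL in a functional assay on cells (Mast cell, Rattus norvegicus) for inhibition, with a stated time of 15 min (a higher number here means that more compound is needed for the effect, a lower number that less compound is needed), the lowest of the two numbers measured so far. Compound 1 `Cc1ccc2oc(C(=O)Nc3nnn[nH]3)cc(=O)c2c1` gives 0.075 ug/mL, a gap to compound 2 that stays within the scatter, so no order between them is claimed. Compound 3 `O=C(O)CCCNC(=O)c1cc(=O)c2ccccc2o1` returns only a limit, > 18 ug/mL, and no number. The unmeasured compound 4 `O=C(Nc1nnn[nH]1)c1cc(=O)c2ccc(O)cc2o1` differs from compound 2 in one place: hydrogen in place of methyl on an oxygen on an aromatic ring. Among the compounds with values here, no measured pair in this set isolates that change, so the size of the step in this assay rests on expectation alone: none beyond the scatter, or at most a modest rise in the number. For compound 4 the estimate is 0.08 ug/mL, with a range of 0.03 ug/mL to 0.25 ug/mL, so the expected step is a 1.7-fold higher number from compound 2 to compound 4 (0.22 log units; within the scatter).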

Compound 4, concentration for half-maximal effect: 0.11 ug/mL
Beside the measured number, compound 4's estimate is 1.4-fold (0.14 log units) below it, within the range that was stated.
By their numbers in this assay, from the lowest: compounds 2, 1 and 4 (each within the scatter of the next, the first and the last beyond it). At a limit, above all of these: compound 3.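

In this assay the change from methoxy to hydroxy on the shared core now has a measured size, a 2.3-fold higher number from compound 2 to compound 4 (0.36 log units; beyond the scatter) and so modest but beyond the scatter. The oxygen on the aromatic ring therefore accepts hydrogen in place of methyl at only a modest cost in this assay. This single pair isolates the change, so the reading holds for these two compounds alone.

Going by these compounds, whether an amine or a longer chain on this oxygen would shift the number further remains open. Nothing shown gives a cause for this step.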